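Aryl in place of isobutyl on the amide nitrogen

A few compounds are considered here, and "the series" means these few. Any claim that something is new, unique, unknown or untested is made for them only; others in the source may bear on it.

Compound 1 `CC(C)CNC(=O)c1cc2ccccc2oc1=O` gives 3270 nM in an in vitro assay on BTI-TN-5B1-4 cells for inhibition of Amine oxidase [flavin-containing] B (Homo sapiens), read by fluorescence (a lower number here means a stronger inhibitor, a higher number a weaker inhibitor), the highest number among the three measured compounds. Compound 2 `CCc1ccc(NC(=O)c2cc3ccccc3oc2=O)cc1` gives 890 nM and compound 3 `O=C(Nc1ccc(F)cc1)c1cc2ccccc2oc1=O` gives 67 nM in this assay. Compound 4 `O=C(Nc1ccc(O)cc1)c1cc2ccccc2oc1=O` is not yet measured; it differs from compound 1 by 4-hydroxyphenyl in place of isobutyl on an amide-type nitrogen. The step of a 49-fold lower number from compound 1 to compound 3 (1.69 log units; beyond the scatter) bears directly on this change, as it also puts an aromatic ring on the amide-type nitrogen. Going by the values given here, the step of a 13-fold lower number from compound 2 to compound 3 (1.12 log units; beyond the scatter) shows that the group on that ring matters, the ethyl member giving the weaker number; a hydroxy member has no measured counterpart here. A large fall is expected for compound 4, about a 22-fold lower number from compound 1 to compound 4 (1.34 log units; beyond the scatter). Compound 4 is estimated at 150 nM, within 40 nM to 600 nM.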

Compound 4, half-maximal inhibitory concentration: 800 nM
For compound 4 the middle estimate is 5.3-fold (0.73 log units) below the measured one; the measured number lies above the stated range.
By their numbers in this assay, from the lowest: compound 3; then compounds 4 and 2 (each within the scatter of the next); then compound 1.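

An aromatic ring on the amide-type nitrogen does not by itself bring the whole gain: 4-hydroxyphenyl in place of isobutyl lowers the number only modestly (a 4.1-fold lower number from compound 1 to compound 4 (0.61 log units; beyond the scatter)). The group on that ring counts for more, as hydroxy in place of fluoro costs a large step (a 12-fold higher number from compound 3 to compound 4 (1.08 log units; beyond the scatter)), while hydroxy in place of ethyl stays within the scatter (a 1.1-fold lower number from compound 2 to compound 4 (0.05 log units; within the scatter)). No measurement at hand accounts for these differences.

Open, going by these compounds, is whether fluoro stands alone among ring groups or chloro, methoxy or an amine would match it.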